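Two Measured Compounds and One Expected Value

The source may hold more compounds than are shown below. What is called first, only, known or untested is meant among the compounds shown, and "the series" means these compounds.

Measured so far:
compound 1 `OCCOCn1cnc2c(S)nc(F)nc21`: 170000 nM
compound 2 `O=C(CI)NCc1cn([C@H]2C[C@H](O)[C@@H](CO)O2)c(=O)[nH]c1=O`: 107000 nM

In an ADME assay on L1210/0 cells (Mus musculus) for cytotoxicity, with a stated time of 48 h (on this read-out higher numbers stand for weaker inhibition and lower numbers for stronger inhibition), compound 1 gives 170000 nM and compound 2 gives 107000 nM. Compound 2 has the lower of the two numbers, yet its gap to compound 1 lies within the scatter, so neither can be called the stronger. Compound 3 `CCCc1cn([C@H]2C[C@H](O)[C@@H](CO)O2)c(=O)[nH]c1=O` is not yet measured; it differs from compound 2 by ethyl in place of ((iodomethyl)carbonyl)amino on a saturated chain carbon bound to an aromatic carbon. No measured pair separates the compounds shown, so nothing here tells how large such a step is. A step of about the scatter, or a modest rise, is expected: a 1.9-fold higher number from compound 2 to compound 3 (0.27 log units; within the scatter). Compound 3 is thus expected to give around 200000 nM, between 50000 nM and 800000 nM.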

Compound 3, half-maximal inhibitory concentration: > 200000 nM
Compound 3: only a limit was reported; the forecaster's own chance of this, stated with the estimate: 30%; the middle value sits exactly at the limit.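

In this assay compound 3 is reported only as a limit, > 200000 nM, not as an exact number. Ethyl in place of ((iodomethyl)carbonyl)amino on a saturated chain carbon bound to an aromatic carbon gives an at least 1.8-fold higher number from compound 2 to compound 3 (0.27 log units; that floor lies within the scatter), the first step read at this place, and it offers no sign of stronger inhibition. The full size of the step cannot be read, because compound 3 stands at a limit: the limit of > 200000 nM in this assay, at which 1 of the 3 values shown sits.

The compounds shown leave open whether the iodomethyl part or the carbonyl and its nitrogen matter more. As far as these compounds go, how an amine or a longer chain would read at this place also stays open.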